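Back From the Limit by Shortening the Side Chain

The source may report more compounds than this note shows. Statements on the series, on what has been measured and on what is new or still open speak of the compounds shown alone.

Compound 1, `CCCCCCCOc1ccc(CC[C@@](N)(CO)CCC)cc1`, gives 0.63 mg/kg in a functional assay on the whole organism (spleen, spleen) with Rattus norvegicus as the target; on this read-out higher numbers stand for an effect only at larger amounts of compound and lower numbers for an effect already at smaller amounts.
Compound 2, `CCCCCCCOc1ccc(CCC(N)(CO)CCCC)cc1`, gives > 10 mg/kg in this assay, which is a limit of the assay and not a number.

Compound 2 therefore stands at the limit of > 10 mg/kg in this assay, at which 1 of the 2 values shown sits. Compound 3, `CCCCCCCOc1ccc(CC[C@](N)(CO)CCO)cc1`, differs from compound 2 by a group of 7 heavy atoms (4 carbon, 1 nitrogen, 2 oxygen; no ring) in place of a group of 8 heavy atoms (6 carbon, 1 nitrogen, 1 oxygen; no ring), on a saturated chain carbon, two bonds along the chain from an aromatic carbon. Going by the values given here, the one measured step at this position, an at least 15-fold higher number from compound 1 to compound 2 (1.20 log units; beyond the scatter), shows that changing this group can shift the result strongly. Compound 3 is expected to return to a measurable dose, a step of an at least 6.6-fold lower number from compound 2 to compound 3 (0.82 log units; beyond the scatter). The estimate for compound 3 is 1.5 mg/kg, within 0.4 mg/kg to 10 mg/kg.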

Compound 3, dose for 50% inhibition: 4.2 mg/kg
The estimate for compound 3 lay 2.8-fold (0.45 log units) below the measured number, and the stated range covers the measured number.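

At this position the group with 2 oxygen brings this assay back to a measured dose, with an at least 2.3-fold lower number from compound 2 to compound 3 (0.37 log units; beyond the scatter) in this change. Going by these compounds, the true size of that step stays open, as compound 2 is a limit of the assay and not a number: the limit of > 10 mg/kg in this assay, at which 1 of the 3 values shown sits. The return is only partial, with a 6.7-fold higher number from compound 1 to compound 3 (0.82 log units; beyond the scatter) still separating the two measured compounds.

The compounds shown leave open how an amine or a carboxylic acid would read in this place. They also leave open what part the defined stereocentre plays.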